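A few compounds are considered here, and "the series" means these few. Any claim that something is new, unique, unknown or untested is made for them only; others in the source may bear on it.

Measured in a physicochemical assay for solubility, measured as thermodynamic solubility, at pH 7.4; on this read-out higher numbers stand for higher solubility and lower numbers for lower solubility:
Compound 1 `CC(C)N1Cc2c(NC(c3ccccc3)c3ccccc3)nc(N3CCNCC3)nc2C1=O`: 1000000 nM
Compound 2 `CC(=O)NC1CCN(c2nc(NC(c3ccccc3)c3ccccc3)c3c(n2)C(=O)N(C(C)C)C3)C1`: < 1000 nM, a limit

Compound 2 has no number of its own, only (the limit of < 1000 nM in this assay, at which 1 of the 2 values shown sits). Compound 3 `COCCNc1nc(NC(c2ccccc2)c2ccccc2)c2c(n1)C(=O)N(C(C)C)C2` shares the core of compound 2 and differs from it in one place: (2-methoxyethyl)amino in place of 3-acetamidopyrrolidin-1-yl on an aromatic carbon. There, (2-methoxyethyl)amino takes the place of 3-acetamidopyrrolidin-1-yl on an aromatic carbon, and neither group carries a net charge.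

Going by the values given here, the one measured step at this place is an at least 1000-fold lower number from compound 1 to compound 2 (3.00 log units; beyond the scatter), with 3-acetamidopyrrolidin-1-yl in place of piperazin-1-yl. It is large and beyond the scatter. Among the compounds with values here, no measured compound carries (2-methoxyethyl)amino, so the evidence is thin. Compound 3, like compound 2, lacks the piperazin-1-yl group of compound 1, so it is not expected to return towards the value of compound 1, 1000000 nM. The expected move in this assay is small and stays within the scatter: a step that the limit leaves unreadable from compound 2 to compound 3. Compound 3 is estimated at 700 nM, with an expected range of 150 nM to 3000 nM, and the assay may again report only a limit.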

Compound 3, solubility: < 1000 nM
Compound 3 gave a limit, no number; the forecaster's own chance of this, stated with the estimate: 70%; the middle value is on the limit's open side.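

In this assay, putting (2-methoxyethyl)amino in place of piperazin-1-yl on this aromatic carbon, between two ring nitrogen atoms, gives an at least 1000-fold lower number from compound 1 to compound 3 (3.00 log units; beyond the scatter). The large step seen with 3-acetamidopyrrolidin-1-yl is therefore not confined to that one group: a replacement with a five-membered non-aromatic ring and an open chain with no ring, neither carrying a net charge, both end at a limit rather than a number. The steps between compound 2 and compound 3 cannot be read, and the two groups cannot be ranked against each other, because both compounds sit at the same limit: the limit of < 1000 nM in this assay, at which 2 of the 3 values shown sit.

From the compounds shown here alone, how far compound 2 and compound 3 actually lie past that limit stays open. Going by these compounds, the true size of the drop from compound 1, which gives 1000000 nM, stays open as well. On these data alone, it is also open whether another group at this place, such as 4-methylpiperazin-1-yl, a 2-aminoethylamino chain or a chain ending in a carboxylic acid, would stay at the limit or return towards compound 1.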